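The source may hold more compounds than are shown below. What is called first, only, known or untested is meant among the compounds shown, and "the series" means these compounds.

Measured compounds: compound 1 `CC[C@@H]1C(=O)N(C)c2cnc(Nc3ccc(S(=O)(=O)NCCO)cc3)nc2N1C1CCCC1` gives 344 nM; compound 2 `CC[C@@H]1C(=O)N(C)c2cnc(-n3ccc4cc(C(=O)NCC(C)C)ccc43)nc2N1C1CCCC1` gives 953 nM; compound 3 `CCC1C(=O)N(C)c2cnc(Nc3ccc(S(=O)(=O)NC)cc3)nc2N1c1ccn(C)n1` gives 3750 nM.

In a functional assay on MCF7 cells (Homo sapiens) for antiproliferative activity, read by CCK-8 assay, with a stated time of 72 h (a lower number here means a stronger inhibitor of growth, a higher number a weaker inhibitor of growth), compound 1 stands lowest of the three numbers; compound 2 lies beyond the scatter above it, and compound 3 lies further above it still. Compound 4 `CC[C@@H]1C(=O)N(C)c2cnc(Nc3ccc(S(=O)(=O)NCCCO)cc3)nc2N1C1CCCC1` differs from compound 1 by hydroxymethyl in place of hydroxy on a saturated chain carbon, two bonds along the chain from a sulfonamide nitrogen. Among the measured compounds shown here, no pair of measured compounds differs in only one place, so these data give no direct reading of how large such a step is. The change sits on a saturated chain carbon, two bonds along the chain from a sulfonamide nitrogen, and the expectation is a step of no more than the scatter, in either direction: a 1.2-fold higher number from compound 1 to compound 4 (0.07 log units; within the scatter). Compound 4 is estimated at 400 nM, within a range of 150 nM to 1000 nM.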

Compound 4, concentration for 50% growth inhibition: 363 nM
The estimate for compound 4 lay 1.1-fold (0.04 log units) above the measured number; low and high end bracket the measured number.
By their numbers in this assay, from the lowest: compounds 1 and 4 (each within the scatter of the next); then compound 2; then compound 3.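

In this assay, among the compounds shown here, hydroxymethyl in place of hydroxy on a saturated chain carbon, two bonds along the chain from a sulfonamide nitrogen, gives a 1.1-fold higher number from compound 1 to compound 4 (0.02 log units; within the scatter), the first step between compounds that differ in one place. At this position, then, the 2-hydroxyethyl and 3-hydroxypropyl chains cannot be told apart in this assay. Nothing measured here bears on the reason for this result. The compounds shown leave open whether a longer chain would also stay within the scatter, and whether a terminal amine or carboxylic acid could take the place of the hydroxy. A plain propyl chain would test whether the hydroxy matters at all.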